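A few compounds are considered here, and "the series" means these few. Any claim that something is new, unique, unknown or untested is made for them only; others in the source may bear on it.

Compound 1 `COc1ccc(-c2ccc3c(NCCCNCc4cccc(OC)c4O)ccnc3c2)cc1`: 1600 nM
Compound 2 `COc1ccc(F)cc1CNCCCNc1ccnc2cc(Oc3ccc(F)cc3)ccc12`: 6600 nM
Compound 3 `COc1cccc(Oc2ccc3c(NCCCNCc4ccco4)ccnc3c2)c1`: 15500 nM

These three compounds were tested in an ADME assay on HepG2 cells (Homo sapiens) for cytotoxicity, read by luminescence, CellTiter-Glo and ATP content, with a stated time of 72 h; a lower number here means that less compound is needed, a higher number that more compound is needed for the effect. Compound 1 gives 1600 nM, the lowest of the three numbers. Compound 2 and compound 3 both stand higher, each beyond the usual scatter of repeated measurements.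

Compound 4 `COc1cccc(CNCCCNc2ccnc3cc(Cc4ccc(F)cc4)ccc23)c1O` has not yet been measured. Compared with compound 1, it has 4-fluorobenzyl in place of 4-methoxyphenyl on an aromatic carbon, and the rest of the two structures is the same. Each of the two groups holds one six-membered aromatic ring of carbon only.

The measured compounds differ from one another in more than one place, so the data show no direct measure of this swap in this assay. The best guide is therefore compound 1 at 1600 nM, whose remaining structure compound 4 shares. The expectation is a small move towards a higher number, with no step beyond the scatter. The expected step is a 1.6-fold higher number from compound 1 to compound 4 (0.19 log units; within the scatter). The range is left wider on the upper side, since compound 3 reaches 15500 nM. For compound 4 the estimated value is 2500 nM, with an expected range from 1000 nM to 7000 nM.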

Compound 4, half-maximal effective concentration: 4780 nM
Beside the measured number, compound 4's estimate is 1.9-fold (0.28 log units) below it, within the range that was stated.
By their numbers in this assay, from the lowest: compound 1; then compounds 4 and 2 (each within the scatter of the next); then compound 3.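

In this assay, replacing 4-methoxyphenyl with 4-fluorobenzyl on this aromatic carbon gives a 3.0-fold higher number from compound 1 to compound 4 (0.48 log units; beyond the scatter), so more compound is needed for the effect after the swap. For the compounds shown here, this is the first change in the set that can be read on its own, as the earlier compounds differ from one another in more than one place, and it shows that this position is not indifferent to what it carries: the two groups have the same count of heavy atoms and the same single six-membered aromatic ring of carbon only, yet the number moves beyond the scatter. They do differ in other ways, as fluorine replaces oxygen and the hydrogen-bond acceptor count goes from one to none, but no measurement here says which of these differences, if any, accounts for the step.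

Going by these compounds alone, the single swap changes several features at once, so the role of each remains open. A 4-fluorophenyl group or a 4-methoxybenzyl group on the same carbon would help pull these features apart, showing whether the fluorine or the way the ring is attached matters more.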